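The compounds below may be only part of what the source reports. "The series", "measured", "known", "first", "only" and "open" are said of these compounds alone.

Going by the values given here, compound 1 `CC(C)c1ccc(NC(=O)C2CCN(C/C=C/c3ccccc3)CC2)cc1` is one of three compounds measured in a functional assay on A549 cells (Homo sapiens) for inhibition, read by MTT assay, with a stated time of 72 h (on this read-out higher numbers stand for weaker inhibition and lower numbers for stronger inhibition), where compound 1 gives 9430 nM. Compound 2 `CCCCCc1ccc(NC(=O)C2CCN(C/C=C/c3ccccc3)CC2)cc1` gives 3880 nM, and compound 3 `O=C(Nc1nc2ccc(Br)cc2s1)C1CCN(C/C=C/c2ccccc2)CC1` gives 17700 nM, so compound 1 stands second highest of the three, with compound 3 within the scatter of it and compound 2 below it. Among the compounds with values here, the only measured step, a 2.4-fold lower number from compound 1 to compound 2 (0.39 log units; beyond the scatter), keeps the ring on the amide nitrogen and alters only a group on it. Compound 4 `O=C(NCc1ccccc1)C1CCN(C/C=C/c2ccccc2)CC1` differs from compound 1 by benzyl in place of 4-isopropylphenyl on an amide-type nitrogen. Within the data shown here, no measured step makes this kind of change, while compound 3, with a different ring at that position, sits within the scatter of compound 1. The expected step of a 1.3-fold higher number from compound 1 to compound 4 (0.10 log units; within the scatter) is therefore none beyond the scatter. Compound 4 is estimated at 12000 nM, within a range from 4000 nM to 40000 nM.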

Compound 4, half-maximal inhibitory concentration: > 100000 nM
Compound 4: no number, only a limit (the forecaster's own chance of this, stated with the estimate: 10%); middle value at least 8.3-fold (0.92 log units) from the limit.
By their numbers in this assay, from the lowest: compound 2; then compounds 1 and 3 (each within the scatter of the next). At a limit, above all of these: compound 4.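

In this assay compound 4 gives > 100000 nM, which is a limit of the assay and not a number: the limit of > 100000 nM in this assay, at which 1 of the 4 values shown sits. Benzyl in place of 4-isopropylphenyl still gives an at least 10-fold higher number from compound 1 to compound 4 (1.02 log units; beyond the scatter), so the group on this amide-type nitrogen can matter far more than the earlier pentyl and isopropyl change suggested. Both groups hold one six-membered aromatic ring of carbon only, so such a ring alone does not keep the activity.

Open, on these data alone, is whether the loss goes with the benzyl form or with losing the isopropyl group: an unsubstituted phenyl or a 4-isopropylbenzyl group on that nitrogen would separate the two.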